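A few compounds are considered here, and "the series" means these few. Any claim that something is new, unique, unknown or untested is made for them only; others in the source may bear on it.

Measured compounds:
compound 1, `Cc1c(CCCC(=O)O)c2cccc(/C=C/c3ccc(OCCCCc4ccccc4)cc3)c2n1CC(=O)O`: 1.3 10^-6 cm/s
compound 2, `Cc1c(CCCC(=O)O)c2cccc(/C=C/c3ccc(OCCCCc4c(F)cc(F)c(F)c4F)cc3)c2n1CC(=O)O`: 2.9 10^-6 cm/s
compound 3, `Cc1c(F)cccc1CCCCOc1ccc(/C=C/c2cccc3c(CCCC(=O)O)c(C)n(CC(=O)O)c23)cc1`: 4 10^-6 cm/s

All three were tested in a physicochemical assay for permeability, using PAMPA, with a stated time of 4 h, at pH 6.2, tested at 50 uM; a higher number here means that the compound crosses the layer faster, a lower number that the compound crosses the layer more slowly. Compound 3 has the top number of the three, but the gap a 1.4-fold higher number from compound 2 to compound 3 (0.14 log units; within the scatter) lies within the usual scatter, so compound 2 and compound 3 cannot be told apart on these numbers; only compound 1 sits clearly lower, as shown by a 3.1-fold higher number from compound 1 to compound 3 (0.49 log units; beyond the scatter).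

Compound 4, `Cc1c(CCCC(=O)O)c2cccc(/C=C/c3ccc(OCCCCc4cc(F)c(F)c(F)c4F)cc3)c2n1CC(=O)O`, has not yet been measured. It differs from compound 3 in one place: 2,3,4,5-tetrafluorophenyl in place of 3-fluoro-2-methylphenyl on a saturated chain carbon, four bonds along the chain from an oxygen on an aromatic ring. Among the compounds with values here, two measured steps bear on this change. The step of a 2.2-fold higher number from compound 1 to compound 2 (0.35 log units; beyond the scatter) shows that a tetrafluorophenyl ring in place of a plain phenyl ring gave a modestly higher number. The step of a 1.4-fold higher number from compound 2 to compound 3 (0.14 log units; within the scatter) shows that exchanging that tetrafluorophenyl ring for a 3-fluoro-2-methylphenyl ring moved the number by less than the scatter. Compound 4 carries a 2,3,4,5-tetrafluorophenyl ring, while compound 2 carries a 2,3,4,6-tetrafluorophenyl ring, so compound 2 is its closest measured relative. Because a 1.4-fold higher number from compound 2 to compound 3 (0.14 log units; within the scatter) was within the scatter, for compound 4 the step of a 1.3-fold lower number from compound 3 to compound 4 (0.12 log units; within the scatter) is expected to stay within the scatter as well. Compound 4 is estimated at 3 10^-6 cm/s, with a likely range of 1.8 10^-6 cm/s to 5 10^-6 cm/s.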

Compound 4, apparent permeability: 1.8 10^-6 cm/s
Beside the measured number, compound 4's estimate is 1.7-fold (0.22 log units) above it, within the range that was stated.
By their numbers in this assay, from the lowest: compounds 1, 4, 2 and 3 (each within the scatter of the next, the first and the last beyond it).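

In this assay, the 2,3,4,5-tetrafluorophenyl ring gives a modest drop beyond the scatter when it takes the place of the 3-fluoro-2-methylphenyl ring on this saturated chain carbon (a 2.2-fold lower number from compound 3 to compound 4 (0.35 log units; beyond the scatter)), so a change at this position can separate two substituted rings. Yet the two tetrafluorophenyl rings cannot be told apart (a 1.6-fold lower number from compound 2 to compound 4 (0.21 log units; within the scatter)), and compound 4 cannot be told apart from the plain phenyl compound 1 (a 1.4-fold higher number from compound 1 to compound 4 (0.14 log units; within the scatter)). This adds a caution to the earlier result: compound 2 stood clearly above compound 1 (a 2.2-fold higher number from compound 1 to compound 2 (0.35 log units; beyond the scatter)), but having four fluorines on the ring does not by itself give a number clearly above that of the plain phenyl ring, since compound 4 has four as well and does not clear the scatter.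

Nothing among the data shown explains why these rings behave as they do. Also open, from the compounds shown here alone, is how a ring carrying an amine or a methoxy group, or a single fluorine, would read at this position, and whether a shorter chain between the ring and the oxygen would shift these numbers.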